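Shifting One Fluorine on the Phenyl Amide

The source may hold more compounds than are shown below. What is called first, only, known or untested is meant among the compounds shown, and "the series" means these compounds.

Compound 1, `O=C(c1cccc(F)c1)N1CCN(c2nc(=O)c3cc(C(F)(F)F)cc([N+](=O)[O-])c3s2)CC1`: 0.2 ug/mL
Compound 2, `O=c1nc(N2CCN(CC3CCCCC3)CC2)sc2c([N+](=O)[O-])cc(C(F)(F)F)cc12`: 9.07 ug/mL
Compound 3, `CCCC(=O)N1CCN(c2nc(=O)c3cc(C(F)(F)F)cc([N+](=O)[O-])c3s2)CC1`: 2.46 ug/mL

In a physicochemical assay for solubility, read by HPLC (on this read-out lower numbers stand for lower solubility and higher numbers for higher solubility), compound 1 stands lowest of the three: compound 3 lies a 12-fold higher number from compound 1 to compound 3 (1.09 log units; beyond the scatter) and compound 2 lies a 45-fold higher number from compound 1 to compound 2 (1.66 log units; beyond the scatter). Compound 4, `O=C(c1ccccc1F)N1CCN(c2nc(=O)c3cc(C(F)(F)F)cc([N+](=O)[O-])c3s2)CC1`, keeps every atom of compound 1 and differs only in 2-fluorophenyl in place of 3-fluorophenyl on a carbonyl carbon. Neither measured step bears on this directly, since both replace the whole (3-fluorophenyl)carbonyl or 3-fluorophenyl group rather than relocate the fluorine within it. With the same atoms joined differently, the expected step is a 1.5-fold higher number from compound 1 to compound 4 (0.18 log units; within the scatter), within the usual scatter. Compound 4 is therefore estimated at 0.3 ug/mL, with a range from 0.1 ug/mL to 0.9 ug/mL.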

Compound 4, solubility: 3.1 ug/mL
Beside the measured number, compound 4's estimate is 10-fold (1.01 log units) below it; measured number outside the range, above it.
By their numbers in this assay, from the lowest: compound 1; then compounds 3 and 4 (each within the scatter of the next); then compound 2.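

In this assay, relocating the fluorine changes no atom count, yet 2-fluorophenyl in place of 3-fluorophenyl on a carbonyl carbon gives a large change (a 16-fold higher number from compound 1 to compound 4 (1.19 log units; beyond the scatter)), so the fluorine's place on this group matters, which the earlier whole-group swaps could not show. With 2-fluorophenyl, the carbonyl compound now sits level with the propyl amide (a 1.3-fold higher number from compound 3 to compound 4 (0.10 log units; within the scatter)) but still apart from the cyclohexylmethyl amine (a 2.9-fold lower number from compound 2 to compound 4 (0.47 log units; beyond the scatter)). No measurement shown here offers a reason for the shift.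

Still open, as far as these compounds go, is whether this holds for atoms other than fluorine, as with a chlorophenyl or pyridyl group on the same carbonyl carbon.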